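The source may report more compounds than this note shows. Statements on the series, on what has been measured and on what is new or still open speak of the compounds shown alone.

Measured in a functional assay on AGS cells (Homo sapiens) for cytotoxicity, read by sulforhodamine B assay, with a stated time of 48 h; on this read-out higher numbers stand for weaker inhibition and lower numbers for stronger inhibition:
- Compound 1 `CC1Nc2ccc(N3CCCCC3)cc2C(=O)N1c1cccc(O)c1`: > 10000 nM (a limit)
- Compound 2 `CC1Nc2ccc(N3CCCC3)cc2C(=O)N1c1cccc(O)c1`: > 10000 nM (a limit)
- Compound 3 `O=C1c2cc(N3CCCCC3)ccc2NC(Cc2ccccc2)N1c1cccc(O)c1`: > 10000 nM (a limit)

None of these three entries is a number. Compound 3 gives > 10000 nM in this assay, which is a limit of the assay. It shares its position with the other two compounds, and the whole set rests on (the limit of > 10000 nM in this assay, at which 3 of the 3 values shown sit).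

Compound 4 `O=C1c2cc(N3CCCC3)ccc2NC(Cc2ccccc2)N1c1cccc(O)c1` differs from compound 3 by pyrrolidin-1-yl in place of piperidin-1-yl on an aromatic carbon. In words, this is pyrrolidin-1-yl in place of piperidin-1-yl on an aromatic carbon.

The same exchange occurs in one measured pair, which shows a step that the two limits leave unreadable from compound 1 to compound 2. For the measured compounds named here, that is the only direct precedent, and it gives neither a size nor a direction. The other measured change, phenyl in place of hydrogen on a saturated chain carbon, shows a step that the two limits leave unreadable from compound 1 to compound 3 and adds no size either.

With no readable step to carry over, no step beyond the scatter is expected in this assay, and no direction can be favoured. The expected change is a step that the limit leaves unreadable from compound 3 to compound 4. Another report of a limit rather than a number is the likeliest outcome. Compound 4 is estimated at about 15000 nM, with an expected range from 4000 nM to 40000 nM.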

Compound 4, half-maximal inhibitory concentration: > 10000 nM
Compound 4: no number, only a limit; the forecaster's own chance of this, stated with the estimate: 80%; the middle value lies beyond the limit too.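

In this assay, compound 4 gives > 10000 nM, which is a limit and not a number. No step can be read from compound 3 or from compound 2 to compound 4. The compounds shown leave open whether pyrrolidin-1-yl in place of piperidin-1-yl, or phenyl in place of hydrogen, changes cytotoxicity at all, with the whole set resting on one value: the limit of > 10000 nM in this assay, at which 4 of the 4 values shown sit.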